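The compounds below may be only part of what the source reports. "The series", "measured", "known", "first", "only" and "open" are said of these compounds alone.

Measured in an ADME assay on Vero cells (Chlorocebus sabaeus) for cytotoxicity, read by MTT assay, with a stated time of 96 h; a lower number here means that less compound is tolerated, a higher number that more compound is tolerated:
- compound 1 `C/C(=N\NC(N)=O)c1ccc2[nH]c(-c3ccc(Cl)cc3)nc2c1`: > 100000 nM
- compound 2 `C/C(=N\NC(N)=O)c1ccc2c(c1)nc(-c1ccccc1)n2C1CCCCC1`: > 100000 nM

Compound 2 stands at > 100000 nM, a limit of the assay and not a number. This is the limit of > 100000 nM in this assay, at which 2 of the 2 values shown sit.

Compound 3 `C/C(=N\NC(N)=O)c1ccc2c(c1)nc(-c1ccc(Cl)cc1)n2C1CCCCC1` has chloro in place of hydrogen on an aromatic carbon, turning phenyl into 4-chlorophenyl: chloro in place of hydrogen on an aromatic carbon. Among the compounds with values here, no measured step shows this change in this assay. Compound 1, which also carries 4-chlorophenyl, gives the limit > 100000 nM, so no change beyond the scatter is expected. The estimated step is a number no higher from compound 2 to compound 3 (the limit leaves the size open). For compound 3 the expected value is 100000 nM, with an estimated range of 40000 nM to 200000 nM.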

Compound 3, half-maximal cytotoxic concentration: > 100000 nM
Compound 3: a limit, no number (the forecaster's own chance of this, stated with the estimate: 70%); the middle value sits exactly at the limit.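

Neither the step from compound 2 to compound 3 nor the step from compound 1 to compound 3 can be read in this assay, as all three compounds sit at one limit: the limit of > 100000 nM in this assay, at which 3 of the 3 values shown sit.

The compounds shown leave open whether chloro or cyclohexyl changes tolerance at all, and at what concentration any of the three would reach half-maximal cytotoxicity.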